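A chloro step on the phenoxy group

The source may report more compounds than this note shows. Statements on the series, on what has been measured and on what is new or still open speak of the compounds shown alone.

Compound 1 `COc1ccc(/C=C/C(=O)/C=C/c2cc3ccccc3nc2Oc2ccccc2)cc1OC`: > 10000 nM
Compound 2 `COc1cc(OC)c(OC)cc1/C=C/C(=O)/C=C/c1cc2ccccc2nc1Oc1ccccc1`: 12200 nM

Among the compounds with values here, in a functional assay on HeLa cells (Homo sapiens) for cytotoxicity, read by MTT assay, with a stated time of 48 h (on this read-out higher numbers stand for weaker inhibition and lower numbers for stronger inhibition), compound 2 gives 12200 nM, the only actual number so far. Compound 1 gives > 10000 nM, which is a limit of the assay and not a number. Within the data shown here, the only measured step is a step that the limit leaves unreadable from compound 1 to compound 2. It swaps in a methoxy group and offers no size to build on.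

Compound 3 `COc1cc(OC)c(OC)cc1/C=C/C(=O)/C=C/c1cc2ccccc2nc1Oc1cccc(Cl)c1` differs from compound 2 by chloro in place of hydrogen on an aromatic carbon, turning phenoxy into 3-chlorophenoxy. Among the measured compounds shown here, no measured step involves chloro, so no step beyond the usual scatter is expected in this assay, and the expectation stays close to compound 2 with its 12200 nM. The estimated change is a 1.4-fold lower number from compound 2 to compound 3 (0.13 log units; within the scatter). The estimate for compound 3 is 9000 nM, with an expected range from 3500 nM to 22000 nM.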

Compound 3, half-maximal inhibitory concentration: > 10000 nM
Compound 3 gave a limit, no number; the forecaster's own chance of this, stated with the estimate: 35%; middle value at least 1.1-fold (0.04 log units) away from the limit.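

Compound 3 gives a limit of the assay and not a number, and no size can be read for the chloro step between compound 2 and compound 3. Going by these compounds, whether 3-chlorophenoxy in place of phenoxy changes the result in this assay at all, and in which direction, stays open.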